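The source may hold more compounds than are shown below. What is called first, only, known or untested is meant among the compounds shown, and "the series" means these compounds.

Measured so far in a functional assay on cells for antagonist activity at C-X-C chemokine receptor type 4 (Homo sapiens), read by fluorescence and calcium flux, with stated times of 25 min and 90 s; a higher number here means a weaker inhibitor, a lower number a stronger inhibitor:
Compound 1 `c1ccc2c(c1)CN[C@@H](CN(CCCCNCc1ccncc1)[C@H]1CCCc3cccnc31)C2` gives 22.7 nM.
Compound 2 `c1ccc(CNCCCCN(C[C@H]2Cc3ccccc3CN2)[C@H]2CCCc3cccnc32)cc1` gives 20.1 nM.
Compound 3 `c1ccc2c(c1)CN[C@@H](CN(CCCCNCC1CCNCC1)[C@H]1CCCc3cccnc31)C2` gives 36.5 nM.

Compound 3 shows the highest of the three numbers in this assay, but the steps of a 1.6-fold higher number from compound 1 to compound 3 (0.21 log units; within the scatter) and a 1.8-fold higher number from compound 2 to compound 3 (0.26 log units; within the scatter) both lie within the scatter, so the three compounds cannot be ranked against one another on these numbers.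

Compound 4 `c1ccc2c(c1)CN[C@@H](CN(CCCCNCC1CCSCC1)[C@H]1CCCc3cccnc31)C2` differs from compound 3 in one place: thian-4-yl in place of piperidin-4-yl on a saturated chain carbon bound to an amine nitrogen. All three measured steps swap the group at this same place, and each of them stayed within the scatter: a 1.1-fold lower number from compound 1 to compound 2 (0.05 log units; within the scatter), a 1.6-fold higher number from compound 1 to compound 3 (0.21 log units; within the scatter), a 1.8-fold higher number from compound 2 to compound 3 (0.26 log units; within the scatter). Within the data shown here, an aromatic ring, a ring holding a basic nitrogen, and a saturated ring with a donor all gave similar numbers, so the group at this position appears to be tolerated broadly, with no compound among the three going against this. A saturated sulfur ring is therefore expected to behave much the same, with a 1.3-fold lower number from compound 3 to compound 4 (0.12 log units; within the scatter) as the expected step, not beyond the scatter in either direction. For compound 4 in this assay the estimate is 28 nM, with a range from 12 nM to 70 nM.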

Compound 4, half-maximal inhibitory concentration: 69.6 nM
Estimate against measurement, compound 4: 2.5-fold (0.40 log units) below; low and high end bracket the measured number.
By their numbers in this assay, from the lowest: compounds 2, 1, 3 and 4 (each within the scatter of the next, the first and the last beyond it).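

In this assay the step from piperidin-4-yl to thian-4-yl, a 1.9-fold higher number from compound 3 to compound 4 (0.28 log units; within the scatter), stays within the scatter, so a saturated ring without the donor of piperidin-4-yl is not clearly set apart from compound 3. Among these compounds, the position is still not wholly indifferent: a 3.5-fold higher number from compound 2 to compound 4 (0.54 log units; beyond the scatter) and a 3.1-fold higher number from compound 1 to compound 4 (0.49 log units; beyond the scatter) are the first steps at this place to pass beyond the scatter, though both are modest, so thian-4-yl sits measurably apart from the phenyl and pyridin-4-yl groups. No measurement here bears on what lies behind these differences.

Left open is whether a cyclohexyl ring, with carbon in place of the sulfur, would fall nearer compound 4 or the aromatic compounds. The compounds shown also leave open how a carboxylic acid or an open alkyl chain would fare at this place.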